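Phenyl for cyclohexyl on the amine nitrogen, second pair

This account rests on a few compounds, and the source may have more. Where it says the series, first, only, none or still open, it means among the compounds named here.

Compound 1 `Brc1ccc(C(CC/N=C(/NCCCc2c[nH]cn2)NC2CCCCC2)c2ccccn2)cc1` and compound 2 `Brc1ccc(C(CC/N=C(/NCCCc2c[nH]cn2)Nc2ccccc2)c2ccccn2)cc1` share one core and differ in a single place: phenyl in place of cyclohexyl on an amine nitrogen. In a functional assay on ileum for antagonist activity at histamine H1 receptor (Cavia porcellus) (on this read-out higher numbers stand for higher potency (the scale is a negative logarithm) and lower numbers for lower potency), compound 1 gives 5.42, and compound 2 gives 5.81; the step of a number 0.39 log units higher from compound 1 to compound 2 (beyond the scatter).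

Compound 3 `Clc1ccc(C(CCC/N=C(/NCCCc2c[nH]cn2)NC2CCCCC2)c2ccccn2)cc1Cl` is built on a second core; the difference between the two cores is not broken down here. In this assay compound 3 gives 5.76, which lies within the scatter of compound 2 and beyond the scatter from compound 1.

Compound 4 `Clc1ccc(C(CCC/N=C(/NCCCc2c[nH]cn2)Nc2ccccc2)c2ccccn2)cc1Cl` has not yet been measured in this assay. It stands to compound 3 as compound 2 stands to compound 1: phenyl in place of cyclohexyl on an amine nitrogen. The surroundings of the place are worded identically in both pairs, so this is the same change made on the second core. The step from compound 3 to compound 4 is expected to read a number 0.39 log units higher from compound 3 to compound 4 (beyond the scatter), resting on the single earlier occurrence, where it gave a number 0.39 log units higher from compound 1 to compound 2 (beyond the scatter); with one precedent only, the range is kept wide. For compound 4 the expected value in this assay is 6.15, between 5.75 and 6.55.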

Compound 4, negative logarithm of the antagonist equilibrium constant: 5.5
Compound 4: middle estimate off by 0.65 log units, on the high side; the whole stated range lies above it.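

In this assay the phenyl in place of cyclohexyl on an amine nitrogen gives a number 0.26 log units lower from compound 3 to compound 4 (within the scatter) and so leaves compound 3 and compound 4 indistinguishable on the second core. The change therefore does not carry over as a fixed increment between these two cores: the same change on two cores in this assay, a number 0.39 log units higher (beyond the scatter) from compound 1 to compound 2 and a number 0.26 log units lower (within the scatter) from compound 3 to compound 4, 0.65 log units apart, beyond the scatter of two such steps
With a single pair on each core, this does not show which feature of the cores goes with the gap, nor does it give a rule for any third core.

Open is which part of the difference between the two cores goes with the gap, as no pair shown isolates one part of that difference. Also open, from the compounds shown here alone, is how a benzyl or a cyclopentyl on the same amine nitrogen would read on each core, and whether either would follow the pattern of compound 1 and compound 2 or that of compound 3 and compound 4.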